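From cyclohexyl to oxan-4-yl on a saturated chain carbon

This account rests on a few compounds, and the source may have more. Where it says the series, first, only, none or still open, it means among the compounds named here.

Measured so far in a physicochemical assay for lipophilicity, at pH 7.4 (on this read-out higher numbers stand for higher lipophilicity and lower numbers for lower lipophilicity), are two compounds:
compound 1 `O=C(O)c1ccc(NC(=O)[C@H](CC2CCCCC2)n2cnc(S(=O)(=O)C3CC3)c2)nc1` gives -0.25
compound 2 `O=C(O)c1ccc(NC(=O)[C@H](CC2CCCCC2)n2cnc(S(=O)(=O)C3CCC3)c2)nc1` gives 0.15

Of these two, compound 2 stands highest at 0.15 on this scale, with compound 1 lower by a margin beyond the scatter. The next compound is compound 3 `O=C(O)c1ccc(NC(=O)[C@H](CC2CCOCC2)n2cnc(S(=O)(=O)C3CCC3)c2)nc1` and its difference from compound 2 is oxan-4-yl in place of cyclohexyl on a saturated chain carbon, two bonds along the chain from an aromatic nitrogen and a carbonyl carbon with oxan-4-yl in place of cyclohexyl on a saturated chain carbon.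

Among the measured compounds shown here, only one measured step exists, a number 0.40 log units higher from compound 1 to compound 2 (beyond the scatter) and it was modest, with cyclobutyl in place of cyclopropyl on a sulfonyl sulfur. That step lies at a different place, so it serves as a yardstick of size and not as a direct precedent. For the measured compounds named here, no measured step covers the exchange of cyclohexyl for oxan-4-yl. The entering ring carries a hydrogen-bond acceptor and the leaving ring none, and on that count a fall larger than the modest step is expected in this assay for this pair. The expected change is a number 1.10 log units lower from compound 2 to compound 3 (beyond the scatter) by this estimate. For compound 3 the estimated value is -0.95 within an expected range from -1.5 to -0.4 in this series.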

Compound 3, distribution coefficient: -1.55
Estimate against measurement, compound 3: 0.60 log units above, outside the stated range (below it).
By their numbers in this assay, from the lowest: compound 3; then compound 1; then compound 2.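

Among the compounds shown here, at this saturated chain carbon, two bonds along the chain from an aromatic nitrogen and a carbonyl carbon, oxan-4-yl in place of cyclohexyl gives a number 1.70 log units lower from compound 2 to compound 3 (beyond the scatter) in this assay, the first reading of any change at this position. The two rings have the same count of 6 heavy atoms, yet this large step outsizes the modest one for cyclobutyl in place of cyclopropyl on the sulfonyl sulfur, which reads a number 0.40 log units higher from compound 1 to compound 2 (beyond the scatter), so this position can move the read-out further than that earlier change did. The data shown offer no measurement that would explain the size of the step.

Going by these compounds, whether the exchange of cyclohexyl for oxan-4-yl would move the read-out as far with cyclopropyl on the sulfonyl sulfur stays open, since oxan-4-yl appears here only with cyclobutyl. Also open, on these data alone, is how this chain carbon would read with other groups in place of the ring, such as a piperidine carrying an amine nitrogen, a difluorocyclohexyl or a longer chain, any of which could show whether the step belongs to the ring oxygen alone.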